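A few compounds are considered here, and "the series" means these few. Any claim that something is new, unique, unknown or untested is made for them only; others in the source may bear on it.

Compound 1 `Nc1nc(N)c(CCCN(Cc2ccc(NC(CCC(=O)O)C(=O)O)cc2)c2ccc([N+](=O)[O-])c(F)c2F)c(O)n1`, > 100000 nM. Compound 2 `Nc1nc(N)c(CCCN(Cc2ccc(NC(CCC(=O)O)C(=O)O)cc2)c2cc(F)cc(F)c2[N+](=O)[O-])c(O)n1`, > 100000 nM.

In a functional assay on CCRF-CEM cells (Homo sapiens) for cytotoxicity, in the absence of a further agent (on this read-out lower numbers stand for stronger inhibition and higher numbers for weaker inhibition), compound 1 reaches only a limit, > 100000 nM. Compound 2 likewise gives only a limit in this assay, > 100000 nM. For the measured compounds named here, the single step between measured compounds, a step that the two limits leave unreadable from compound 1 to compound 2, therefore cannot be read. Compound 3 `Nc1nc(N)c(CCCN(Cc2ccc(NC(CCC(=O)O)C(=O)O)cc2)c2ccc([N+](=O)[O-])c(F)c2[N+](=O)[O-])c(O)n1` has not yet been measured in this assay. It differs from compound 1 in one place: nitro in place of fluoro on an aromatic carbon. Going by the values given here, no measured step bears directly on this change, and the one step recorded, from compound 1 to compound 2, yields no size. What the data do show is the limit of > 100000 nM in this assay, at which 2 of the 2 values shown sit, so compound 3 is expected to sit at that limit as well, a step that the limit leaves unreadable from compound 1 to compound 3 whose size cannot be fixed. The estimate for compound 3 in this assay is 150000 nM, between 50000 nM and 500000 nM, with the result most likely reported only as a limit.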

Compound 3, half-maximal inhibitory concentration: 46000 nM
Beside the measured number, compound 3's estimate is 3.3-fold (0.51 log units) above it; measured number outside the range, below it.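

In this assay, for the compounds shown here, nitro in place of fluoro on this aromatic carbon, ortho to a fluoro group and ortho to a large group, gives the first step that can be read: an at least 2.1-fold lower number from compound 1 to compound 3 (0.33 log units; beyond the scatter). Going by these compounds alone, the step from compound 1 to compound 2 cannot be read, so compound 3 is the first sign that a change on this aryl group can register in the read-out at all. Even so, the series remains mostly at the limit: the limit of > 100000 nM in this assay, at which 2 of the 3 values shown sit.

The compounds shown leave open whether an amine, a nitrile or a carboxylic acid on this carbon would also lower the number. They also leave open the full size of the step, and whether a nitro group in place of the remaining fluoro group would lower the number further.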